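The compounds below may be only part of what the source reports. "The series", "measured", "known", "first", "only" and "open" are said of these compounds alone.

The measured compounds:
compound 1, `C[C@@H]1CC/C(=N\Nc2ccccc2)c2ncc(C(=O)O)c(=O)n21`, 54.8 umol/kg
compound 2, `O=C(O)C1=CNC2=C(/C=N/c3ccccc3)CCN2C1=O`, 15.4 umol/kg

Compound 1 `C[C@@H]1CC/C(=N\Nc2ccccc2)c2ncc(C(=O)O)c(=O)n21` and compound 2 `O=C(O)C1=CNC2=C(/C=N/c3ccccc3)CCN2C1=O` have both been tested in a functional assay on the whole organism with Rattus norvegicus as the target; a lower number here means that less compound is needed, a higher number that more compound is needed for the effect. In this assay compound 1 gives 54.8 umol/kg, while compound 2 gives 15.4 umol/kg. Of these two numbers, compound 2 holds the lower one, and the gap to compound 1 lies beyond the usual scatter of the measurement. Within the data shown here, no pair of measured compounds differs in only one place, so no single structural step has yet been characterised.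

Compound 3 `CC1CC(/C=N/c2ccccc2)=C2NC=C(C(=O)O)C(=O)N21` differs from compound 2 in a single place: methyl in place of hydrogen on a saturated ring carbon. Among the measured compounds shown here, nothing measured so far shows how such a change behaves on this core. Compound 3 is therefore expected to stay close to compound 2, with an estimated step of a 1.2-fold higher number from compound 2 to compound 3 (0.07 log units; within the scatter), which would lie within the scatter. Compound 3 is expected to give 18 umol/kg, in a range from 7 umol/kg to 45 umol/kg.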

Compound 3, dose for 50% inhibition: 20.2 umol/kg
Compound 3: the middle estimate sits 1.1-fold (0.05 log units) below what was measured; the measured number falls inside the stated range.
By their numbers in this assay, from the lowest: compounds 2 and 3 (each within the scatter of the next); then compound 1.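

In this assay, methyl in place of hydrogen on a saturated ring carbon gives a 1.3-fold higher number from compound 2 to compound 3 (0.12 log units; within the scatter). Among these compounds, this is the first single-place step, and it shows that this carbon, next to the ring nitrogen, can carry a methyl without moving the dose beyond the scatter of the measurement. Nothing available explains why the step is this small.

The compounds shown leave open whether an ethyl, a longer chain or a hydroxyl on the same carbon would also stay within the scatter of compound 2. They also leave open whether a phenyl at this carbon, with more heavy atoms than methyl, would keep the dose needed in the same range or shift it beyond the scatter.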